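A few compounds are considered here, and "the series" means these few. Any claim that something is new, unique, unknown or untested is made for them only; others in the source may bear on it.

Measured so far in a functional assay on CWR22R cells (Homo sapiens) for antiproliferative activity, read by propidium iodide staining, with a stated time of 96 h; a higher number here means a weaker inhibitor, a lower number a stronger inhibitor:
Compound 1 `CC(O)(COc1cccc(S(F)(F)(F)(F)F)c1)C(=O)Nc1ccc([N+](=O)[O-])cc1C(F)(F)F` gives 15500 nM
Compound 2 `CC(O)(CS(=O)(=O)c1ccc(F)cc1)C(=O)Nc1ccc(S(F)(F)(F)(F)F)cc1` gives 20600 nM

Compound 2 stands within the scatter of compound 1, and the two numbers cannot be ranked. Compound 3 `CC(O)(CS(=O)(=O)c1ccccc1OC(F)(F)F)C(=O)Nc1ccc(S(F)(F)(F)(F)F)cc1` keeps the core of compound 2 and carries 2-(trifluoromethoxy)phenyl in place of 4-fluorophenyl on a sulfonyl sulfur. Within the data shown here, no measured pair differs in one place, and nothing yet sizes such a change. Starting from compound 2 at 20600 nM as the only anchor, no step beyond the scatter is expected in this assay in either direction. The estimated step is small (a 1.3-fold lower number from compound 2 to compound 3 (0.11 log units; within the scatter)). Compound 3 is expected at 16000 nM with an estimated range from 6000 nM to 40000 nM as its likely span.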

Compound 3, half-maximal inhibitory concentration: 16000 nM
For compound 3 middle estimate and measured number coincide at the digits printed; the measured number falls inside the stated range.
By their numbers in this assay, from the lowest: compounds 1, 3 and 2 (each within the scatter of the next).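

In this assay, among these compounds, the step at this position (a 1.3-fold lower number from compound 2 to compound 3 (0.11 log units; within the scatter)) gives the first sized change on the sulfonyl sulfur: 2-(trifluoromethoxy)phenyl, with more heavy atoms and a hydrogen-bond acceptor, reads like 4-fluorophenyl. Swapping these two aryl groups therefore leaves no difference that can be told from the scatter. No measurement at hand explains this result. Going by these compounds, whether a plain phenyl, an amine or a carboxylic acid on this ring would separate from these values stays open. So does whether any group on the sulfonyl sulfur can move the number beyond the scatter.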